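The source may hold more compounds than are shown below. What is called first, only, known or untested is meant among the compounds shown, and "the series" means these compounds.

In a physicochemical assay for lipophilicity (on this read-out lower numbers stand for lower lipophilicity and higher numbers for higher lipophilicity), compound 2 `COc1c(OC)c(OC(=O)C(C)(C)C)c2cc(Cl)ccc2c1OC(=O)C(C)(C)C` gives 6.6, the highest of the three measured numbers, with compound 1 `COc1c(OC)c(OC(=O)C(C)(C)C)c2ccccc2c1OC(=O)C(C)(C)C` at 5.69 and compound 3 `CCOc1c(OCC)c(OC(=O)CC)c2cc(Cl)ccc2c1OC(=O)CC` at 5.2. Compound 4 `COc1ccc2c(OC(=O)C(C)(C)C)c(OC)c(OC)c(OC(=O)C(C)(C)C)c2c1` differs from compound 2 by one change: methoxy in place of chloro on an aromatic carbon. Among the measured compounds shown here, the one measured step that bears on this is a number 0.91 log units higher from compound 1 to compound 2 (beyond the scatter), with chloro in place of hydrogen on an aromatic carbon. For the measured compounds named here, no measured step involves methoxy, and compound 3 differs from compound 2 in more than one place. A step of comparable size in the opposite direction in this assay is therefore expected, estimated as a number 0.90 log units lower from compound 2 to compound 4 (beyond the scatter). For compound 4 the estimated value is 5.7, with an expected range from 5.3 to 6.1.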

Compound 4, partition coefficient: 5.4
Compound 4: middle estimate off by 0.30 log units, on the high side; the range from low to high includes it.
By their numbers in this assay, from the lowest: compounds 3, 4 and 1 (each within the scatter of the next, the first and the last beyond it); then compound 2.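

At this position, this assay separates chloro from methoxy, with a number 1.20 log units lower from compound 2 to compound 4 (beyond the scatter). Methoxy and hydrogen cannot be told apart there, with a number 0.29 log units lower from compound 1 to compound 4 (within the scatter). Among these three groups on the shared core, only the chloro of compound 2 stands apart, while compound 1 and compound 4 stay together. Nothing available explains why the groups fall this way. As far as these compounds go, whether an amine, a carboxylic acid or a longer alkoxy chain at this position would stay with hydrogen and methoxy or stand apart as chloro does remains open.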